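Ester ring size step across two furan cores

A few compounds are considered here, and "the series" means these few. Any claim that something is new, unique, unknown or untested is made for them only; others in the source may bear on it.

Compound 1 `CC1=C(C(=O)OC2CCC2)C(c2ccco2)NC(=O)N1` gives 19% in an assay on membranes from CHO cells for displacement of a labelled ligand from adenosine receptor A1 (Homo sapiens), read by scintillation counting, with a stated time of 60 min, tested at 1 uM; on this read-out higher numbers stand for more inhibition at the one concentration tested (going by the name of the read-out) and lower numbers for less inhibition. Compound 2 `CC1=C(C(=O)OC2CCCC2)C(c2ccco2)NC(=O)N1` carries the change cyclopentyl in place of cyclobutyl on an oxygen next to a carbonyl group and gives 1% in this assay, a step of a number 18 percentage points lower from compound 1 to compound 2 (beyond the scatter). Compound 3 `CC1=C(C(=O)OC2CCC2)C(c2ccoc2)NC(=O)N1` differs from compound 1 in its core by furan-3-yl in place of furan-2-yl on a saturated ring carbon; in this assay compound 3 gives 20%, a step of a number 1 percentage points higher from compound 1 to compound 3 (within the scatter). Compound 4 `CC1=C(C(=O)OC2CCCC2)C(c2ccoc2)NC(=O)N1` is not yet measured; it differs from compound 3 by cyclopentyl in place of cyclobutyl on an oxygen next to a carbonyl group, the same change as from compound 1 to compound 2, made at the same place. Within the data shown here, for compound 4 the expected step is a number 17 percentage points lower from compound 3 to compound 4 (beyond the scatter) because a number 18 percentage points lower from compound 1 to compound 2 (beyond the scatter) is the only earlier instance of this change and compound 1 and compound 3 start within scatter of each other. Compound 4 is expected to give 3% in this assay, with a range from -6% to 13%.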

Compound 4, a percentage reported as inhibition, at one concentration (the size of the read-out at that concentration, not a potency): 6%
For compound 4 the middle estimate is 3 percentage points below the measured one; the range from low to high includes it.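

In this assay, cyclopentyl in place of cyclobutyl on the furan-3-yl core gives a number 14 percentage points lower from compound 3 to compound 4 (beyond the scatter), and this step agrees with the one on the furan-2-yl core: the same change on two cores in this assay, a number 18 percentage points lower (beyond the scatter) from compound 1 to compound 2 and a number 14 percentage points lower (beyond the scatter) from compound 3 to compound 4, 4 percentage points apart, within the scatter of two such steps. The furan-3-yl in place of furan-2-yl change, now read with cyclopentyl, gives a number 5 percentage points higher from compound 2 to compound 4 (within the scatter), and it too agrees with its earlier instance: the same change on two cores in this assay, a number 1 percentage points higher (within the scatter) from compound 1 to compound 3 and a number 5 percentage points higher (within the scatter) from compound 2 to compound 4, 4 percentage points apart, within the scatter of two such steps. The transfer is shown only between these two closely related cores, for a single ring change at one concentration, and it does not show that the step would hold on other cores or say why it arises.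

Open, from the compounds shown here alone, is whether a cyclohexyl ring or an open chain such as isopropyl on the same oxygen would continue the step from cyclobutyl to cyclopentyl. Also open, going by these compounds, is how a phenyl ring in place of the furan would read.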